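Phenyl in place of methyl on an aromatic nitrogen

A few compounds are considered here, and "the series" means these few. Any claim that something is new, unique, unknown or untested is made for them only; others in the source may bear on it.

Compound 1 `NCCCCCCNC(=O)c1c(O)c2ccccc2n(-c2ccccc2)c1=O` — 68.8%
Compound 2 `Cn1c(=O)c(C(=O)NCCCCCCNC(=O)CCCCC2CCSS2)c(O)c2ccccc21` — 53%

In a functional assay on the whole organism (strain Fischer 344) for inhibition, with Rattus norvegicus as the target, read by paw edema, at a dose of 0.01 mmol/kg by the intraperitoneal route (on this read-out higher numbers stand for more inhibition at the one dose given (going by the name of the read-out) and lower numbers for less inhibition), compound 1 gives 68.8%. Compound 2 gives 53%, the lower of the two numbers, a gap beyond the scatter. Compound 3 `O=C(CCCCC1CCSS1)NCCCCCCNC(=O)c1c(O)c2ccccc2n(-c2ccccc2)c1=O` is not yet measured; it differs from compound 2 by phenyl in place of methyl on an aromatic nitrogen. Going by the values given here, no measured pair isolates this change, so its size is unknown. Because compound 1 with a phenyl at the same place gives 68.8%, the step is expected upward. For compound 3 a value of 62% is estimated, between 46% and 78%. The expected step of a number 9 percentage points higher from compound 2 to compound 3 (within the scatter) lies near the edge of the scatter.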

Compound 3, a percentage reported as inhibition, in the whole organism at one dose (the size of the read-out at that dose, not a potency): 50%
Estimate against measurement, compound 3: 12 percentage points above; low and high end bracket the measured number.
By their numbers in this assay, from the lowest: compounds 3 and 2 (each within the scatter of the next); then compound 1.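

In this assay, phenyl in place of methyl on the aromatic nitrogen now has a direct reading: a number 3 percentage points lower from compound 2 to compound 3 (within the scatter), so this position shows no readable change with the group of 11 heavy atoms on the amine nitrogen. By contrast, placing that group on the amine nitrogen with phenyl held constant gives a number 18.8 percentage points lower from compound 1 to compound 3 (beyond the scatter). The higher value of compound 1 therefore does not carry over to compound 3 at this dose.

Open, from the compounds shown here alone, is whether ethyl or benzyl on the aromatic nitrogen would read differently, and whether methyl there changes the value when the amine stays free. Nothing at hand explains these results.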